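Hydroxyl in place of a disulfide on a naphthoquinone selenide

A few compounds are considered here, and "the series" means these few. Any claim that something is new, unique, unknown or untested is made for them only; others in the source may bear on it.

The study concerns a small set of selenium-bearing quinone esters examined in an ADME assay on PHF cells (Homo sapiens) for cytotoxicity, read by MTT assay, with a stated time of 24 h; on this read-out lower numbers stand for stronger inhibition and higher numbers for weaker inhibition. Compound 1 `CC1=C([Se]CC(OC(=O)CC[Se]c2ccccc2)C(=O)NCCCCCC(=O)OCc2ccccc2)C(=O)c2ccccc2C1=O` gives 6000 nM in this assay. Compound 2 `CC1=C([Se]CC(OC(=O)[C@@H](CSSC(C)(C)C)NC(=O)OC(C)(C)C)C(=O)NC(C)(C)C)C(=O)c2ccccc2C1=O` gives 4000 nM in this assay, and the two numbers for compound 1 and compound 2 lie within the usual scatter of each other, so neither can be called more or less cytotoxic on these data. Compound 3 `CC1=C(SCCC(=O)OC(C[Se]C2=C(C)C(=O)c3ccccc3C2=O)C(=O)NC(C)(C)C)C(=O)c2ccccc2C1=O` was also prepared, but in this assay compound 3 stands only as "not determined" (no result reported), with no result reported for it.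

Compound 4 `CC1=C([Se]CC(OC(=O)[C@@H](CO)NC(=O)OC(C)(C)C)C(=O)NC(C)(C)C)C(=O)c2ccccc2C1=O` differs from compound 2 in one place: hydroxy in place of ((tert-butyl)sulfanyl)sulfanyl on a saturated chain carbon, two bonds along the chain from an amide-type nitrogen and a carbonyl carbon. For the measured compounds named here, no measured pair in the set shares this change, so its effect cannot be read from the data. He expects the step from compound 2 to compound 4 to be small, of the order of the scatter, and if anything toward a slightly higher number, and so estimates it as a 1.5-fold higher number from compound 2 to compound 4 (0.18 log units; within the scatter). On that basis compound 4 is expected to give about 6000 nM in this assay, with a likely range from 2500 nM to 15000 nM.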

Compound 4, half-maximal inhibitory concentration: 7000 nM
Beside the measured number, compound 4's estimate is 1.2-fold (0.07 log units) below it, within the range that was stated.
By their numbers in this assay, from the lowest: compounds 2, 1 and 4 (each within the scatter of the next).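

In this assay, for the compounds shown here, replacing ((tert-butyl)sulfanyl)sulfanyl with hydroxy gives a 1.8-fold higher number from compound 2 to compound 4 (0.24 log units; within the scatter), the first step in the set that can be read at this position. On a saturated chain carbon, two bonds along the chain from an amide-type nitrogen and a carbonyl carbon, the sulfur-bearing group can therefore give way to hydroxy without a difference that this read-out can resolve. Nothing available bears on what lies behind this result.

As far as these compounds go, whether an amine or a carboxylic acid in place of the hydroxy, or a longer chain carrying it, would also stay within the scatter of compound 2 remains open. The compounds shown carry this change on a single background, so whether it would behave in the same way with another ester or amide portion also remains open.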